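The compounds below may be only part of what the source reports. "The series", "measured", "known", "first", "only" and "open" are said of these compounds alone.

Going by the values given here, compound 1 `C/C(C(=O)NC1CC1)=C(/C)c1ccc(F)cc1` is one of two compounds measured in a toxicity assay on the whole organism (strain Icem-CET (SPF Caw)) for cytotoxicity, with Mus musculus as the target; on this read-out lower numbers stand for an effect already at smaller amounts and higher numbers for an effect only at larger amounts of compound; compound 1 gives 70 mg/kg, the lower of the two numbers, while compound 2 `C#CCNC(=O)/C(C)=C(\C)c1ccc(F)cc1` gives 100 mg/kg. Among the compounds with values here, the only measured step, a 1.4-fold higher number from compound 1 to compound 2 (0.15 log units; within the scatter), concerns propargyl in place of cyclopropyl on an amide-type nitrogen. Within the data shown here, compound 3 `C/C(C(=O)NC1CC1)=C(/C)c1ccc(C)cc1` differs from compound 1 by methyl in place of fluoro on an aromatic carbon, a change at the aromatic ring that no measured step touches. With nothing pointing in either direction, the step from compound 1 to compound 3 is expected to stay within the scatter, at a 1.1-fold higher number from compound 1 to compound 3 (0.03 log units; within the scatter). Compound 3 is therefore estimated at 75 mg/kg, between 35 mg/kg and 160 mg/kg.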

Compound 3, dose for half-maximal effect: 150 mg/kg
Estimate against measurement, compound 3: 2.0-fold (0.30 log units) below; the measured number falls inside the stated range.
By their numbers in this assay, from the lowest: compounds 1, 2 and 3 (each within the scatter of the next, the first and the last beyond it).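

Methyl in place of fluoro on an aromatic carbon, para to a large group, gives a 2.1-fold higher number from compound 1 to compound 3 (0.33 log units; beyond the scatter) in this assay. This shows that the number can respond to a swap of a single heavy atom at this position, a change that the earlier step at the amide nitrogen, which stayed within the scatter, could not reveal. No measurement shown here gives a cause for this step.

Still open, as far as these compounds go, is how other groups at this position, such as chloro, methoxy or an amine, would read, and whether the same swap would give a similar step with the propargyl amide of compound 2.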